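A few compounds are considered here, and "the series" means these few. Any claim that something is new, unique, unknown or untested is made for them only; others in the source may bear on it.

Working notes on the series. Compound 1 `CCOc1cc(C(C)(C)C)ccc1C1=NC(c2ccc(Cl)cc2)C(c2ccc(Cl)cc2)N1C(=O)N1CCN(Cc2ccc(C(=O)NO)cc2)CC1` and compound 2 `CCOc1cc(C(C)(C)C)ccc1C1=NC(c2ccc(Cl)cc2)C(c2ccc(Cl)cc2)N1C(=O)NCCCCC(=O)Nc1ccccc1N` share the same core and have both been measured in a functional assay on HCT-116 cells (Homo sapiens) for antiproliferative activity, read by CCK-8 assay, with a stated time of 72 h; a higher number here means a weaker inhibitor, a lower number a stronger inhibitor. In this assay, going by the values given here, compound 1 gives 2030 nM, the lowest of the two numbers, while compound 2 gives 13900 nM; the gap between them lies beyond the scatter, and no single-point step connects the two structures.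

Compound 3 `CCOc1cc(C(C)(C)C)ccc1C1=NC(c2ccc(Cl)cc2)C(c2ccc(Cl)cc2)N1C(=O)N1CCN(CCCCCCCC(=O)NO)CC1` has not been measured in this assay. Its difference from compound 1 is 6-(hydroxycarbamoyl)hexyl in place of 4-(hydroxycarbamoyl)phenyl on a saturated chain carbon bound to an amine nitrogen in a ring, so the group that enters has no ring where the group that leaves had one six-membered aromatic ring. Among the compounds with values here, no measured pair shows this kind of change, so the step from compound 1 to compound 3 is expected to be small, at most near the edge of the scatter, and is expected to read as a 1.5-fold higher number from compound 1 to compound 3 (0.17 log units; within the scatter). Compound 3 is estimated at 3000 nM in this assay, with a likely range from 1000 nM to 10000 nM.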

Compound 3, half-maximal inhibitory concentration: 1710 nM
For compound 3 the middle estimate is 1.8-fold (0.24 log units) above the measured one; the range from low to high includes it.
By their numbers in this assay, from the lowest: compounds 3 and 1 (each within the scatter of the next); then compound 2.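

In this assay, going by these compounds alone, the change to 6-(hydroxycarbamoyl)hexyl in place of 4-(hydroxycarbamoyl)phenyl, on a saturated chain carbon bound to an amine nitrogen in a ring, reads as a 1.2-fold lower number from compound 1 to compound 3 (0.07 log units; within the scatter) and is the only single-point step at this position so far. In this one pair, the six-membered aromatic ring of the leaving group is not needed to keep the number, as an open chain with the same count of heavy atoms serves equally well. Nothing on hand bears on why the two groups read alike.

From the compounds shown here alone, whether the number holds with a longer chain or a shorter chain at this place remains open. Also open, going by these compounds, is what a carboxylic acid in place of the hydroxycarbamoyl end would do to the reading in this assay.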